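A few compounds are considered here, and "the series" means these few. Any claim that something is new, unique, unknown or untested is made for them only; others in the source may bear on it.

Compound 1 `CN(Cc1ccccc1)C(=O)C1CCN(C(=O)c2cc3ccccc3n2Cc2ccc(Cl)cc2)CC1` gives 87000 nM
Compound 2 `COc1ccc(Cn2c(C(=O)N3CCC(C(=O)N(C)Cc4ccccc4)CC3)cc3ccccc32)cc1` gives 99200 nM
Compound 3 `CC(=O)n1c(C(=O)N2CCC(C(=O)N(C)Cc3ccccc3)CC2)cc2ccccc21` is not yet measured

Among the compounds with values here, in an ADME assay on BE(2)-C cells (Homo sapiens) for cytotoxicity, read by MTT assay, with a stated time of 20 h (a lower number here means that less compound is tolerated, a higher number that more compound is tolerated), compound 1 and compound 2 stand within the scatter of each other, and compound 2 gives 99200 nM as the second of only two numbers. Compound 3 differs from compound 2 as follows: acetyl in place of 4-methoxybenzyl on an aromatic nitrogen. Within the data shown here, the one measured step, a 1.1-fold higher number from compound 1 to compound 2 (0.06 log units; within the scatter), is only methoxy in place of chloro on an aromatic carbon. Among the measured compounds shown here, no measured step removes the whole group, so the guidance is weak. In this assay no step beyond the scatter is expected, and the estimated step is a 1.2-fold higher number from compound 2 to compound 3 (0.06 log units; within the scatter). For compound 3 the expected value is 115000 nM, with an estimated range of 50000 nM to 260000 nM.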

Compound 3, half-maximal cytotoxic concentration: > 50000 nM
Compound 3 was reported as a limit; the forecaster's own chance of this, stated with the estimate: 30%; the middle value does not contradict the limit.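

In this assay compound 3 gives > 50000 nM, which is a limit and not a number. Within the data shown here, no step from compound 1 or compound 2 to compound 3 can be read. From the compounds shown here alone, whether acetyl in place of 4-methoxybenzyl on the aromatic nitrogen changes the tolerated concentration beyond the scatter stays open.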